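The source may report more compounds than this note shows. Statements on the series, on what has been measured and on what is new or still open speak of the compounds shown alone.

Measured so far in a functional assay on U-266 cells (Homo sapiens) for antiproliferative activity, read by MTT assay, with a stated time of 72 h; a lower number here means a stronger inhibitor, a higher number a weaker inhibitor:
- compound 1 (`N#C/C(=C\c1cccc(Br)n1)C(=O)N[C@@H](CO)c1ccccc1`): 3500 nM
- compound 2 (`C[C@H](NC(=O)/C(C#N)=C/c1cccc(Br)n1)c1cc(C(F)(F)F)cc(C(F)(F)F)c1`): 1500 nM

Of these two, compound 1 holds the higher number, so it is the weaker inhibitor, and compound 2 lies lower by more than the usual scatter of repeats. Compound 3 (`COC(=O)C[C@H](NC(=O)/C(C#N)=C/c1cccc(Br)n1)c1ccccc1`) has not yet been measured. It differs from compound 1 by methoxycarbonyl in place of hydroxy on a saturated chain carbon, two bonds along the chain from an amide-type nitrogen and an aromatic carbon. Within the data shown here, no measured pair isolates this change, so the expectation is tentative: a small move to a lower number in this assay, possibly no larger than the scatter. The expected step is a 1.5-fold lower number from compound 1 to compound 3 (0.18 log units; within the scatter). For compound 3 the estimated value is 2300 nM, with an expected range from 900 nM to 6000 nM.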

Compound 3, half-maximal inhibitory concentration: 3300 nM
For compound 3 the middle estimate is 1.4-fold (0.16 log units) below the measured one; the range from low to high includes it.
By their numbers in this assay, from the lowest: compound 2; then compounds 3 and 1 (each within the scatter of the next).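

In this assay, putting methoxycarbonyl in place of hydroxy on this saturated chain carbon gives a 1.1-fold lower number from compound 1 to compound 3 (0.03 log units; within the scatter) and so no difference that can be told from repeat measurements. Among these compounds, this pair is the first to isolate a change at this position, and it shows that four heavy atoms can stand in place of one, with the hydrogen-bond donor of the hydroxy gone, without a measurable difference in this assay. No measured evidence is available to account for this result.

The compounds shown leave open whether this tolerance extends to other groups at this carbon, such as a carboxylic acid, an amine or a longer chain. They also leave open whether the same change would give a similar result on a different core.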